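The source may report more compounds than this note shows. Statements on the series, on what has been measured and on what is new or still open speak of the compounds shown alone.

Compound 1 `COCC1(COC)Oc2ccc(C#N)cc2[C@@H](Nc2ccc(=S)n(C)n2)[C@@H]1O` gives 0.01 h in an ADME assay on the whole organism (blood) for pharmacokinetics, with Canis familiaris (Canis lupus familiaris) as the target (a lower number here means that the compound disappears faster, a higher number that the compound lasts longer), the lowest of the three measured numbers; compound 2 `COCC1(COC)Oc2ccc(C#N)cc2[C@@H](Nc2ccc(=O)n(Cc3ccccc3)n2)[C@@H]1O` gives 0.0167 h, within the scatter of compound 1, while compound 3 `COCCn1nc(N[C@@H]2c3cc(C#N)ccc3OC(COC)(COC)[C@H]2O)ccc1=O` gives 0.0267 h, beyond it. Compound 4 `COCC1(COC)Oc2ccc(C#N)cc2[C@@H](Nc2ccc(=O)n(CC#N)n2)[C@@H]1O` differs from compound 1 by a group of 10 heavy atoms (6 carbon, 3 nitrogen, 1 oxygen; one six-membered aromatic ring with 2 hetero atoms) in place of a group of 8 heavy atoms (5 carbon, 2 nitrogen, 1 sulfur; one six-membered aromatic ring with 2 hetero atoms), on an amine nitrogen. Going by the values given here, the only measured single-point step, a change of substituent on a saturated chain carbon bound to an aromatic nitrogen, is a 1.6-fold higher number from compound 2 to compound 3 (0.20 log units; within the scatter), which stays within the scatter. Among the compounds with values here, no measured pair isolates the remaining part of the change, and compound 2 sits within the scatter of compound 1. A step no larger than the scatter is therefore expected: a 1.7-fold higher number from compound 1 to compound 4 (0.23 log units; within the scatter). Compound 4 is estimated at 0.017 h, with a range from 0.008 h to 0.035 h.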

Compound 4, half-life: 0.0517 h
Beside the measured number, compound 4's estimate is 3.0-fold (0.48 log units) below it, and the stated range ends below it.
By their numbers in this assay, from the lowest: compounds 1, 2, 3 and 4 (each within the scatter of the next, the first and the last beyond it).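

In this assay, the substituent on the saturated chain carbon bound to an aromatic nitrogen can move the number beyond the scatter: cyano in place of phenyl does so (a 3.1-fold higher number from compound 2 to compound 4 (0.49 log units; beyond the scatter)), while cyano in place of methoxymethyl stays within it (a 1.9-fold higher number from compound 3 to compound 4 (0.29 log units; within the scatter)). The whole group on the amine nitrogen also gives a step beyond the scatter (a 5.2-fold higher number from compound 1 to compound 4 (0.71 log units; beyond the scatter)), but that step changes several features at once. Nothing available explains these steps.

The share of the sulfur-to-oxygen exchange in that larger step remains unresolved. From the compounds shown here alone, how a carboxylic acid or an amine on that chain carbon would compare with cyano also remains open.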